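The source may hold more compounds than are shown below. What is called first, only, known or untested is meant among the compounds shown, and "the series" means these compounds.

Compound 1 `COCC(=O)Nc1cccc(NC(=O)c2cccc(Cl)c2)c1` is reported only as a limit in an in vitro functional assay on HEK293-A cells for antagonist activity at metabotropic glutamate receptor 5 (Rattus norvegicus), read by calcium flux (on this read-out lower numbers stand for stronger inhibition and higher numbers for weaker inhibition), > 30000 nM; this matches (the limit of > 30000 nM in this assay, at which 1 of the 2 values shown sits). Within the data shown here, compound 2 `O=C(Nc1cccc(O)c1)c1cccc(N2C(=O)c3ccccc3C2=O)c1` gives 7790 nM in this assay, the only plain number among the two measured entries, so it stands alone with no measured step to compare against. Compound 3 `O=C(Nc1ccccn1)c1cccc(N2C(=O)c3ccccc3C2=O)c1` differs from compound 2 by pyridin-2-yl in place of 3-hydroxyphenyl on an amide-type nitrogen. Among the measured compounds shown here, no measured pair of this kind exists here, so for compound 3 only a change within the usual scatter is expected a 1.2-fold higher number from compound 2 to compound 3 (0.06 log units; within the scatter), without a clear direction. For compound 3 the estimate in this assay is 9000 nM, with a range from 2500 nM to 30000 nM.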

Compound 3, half-maximal inhibitory concentration: 1260 nM
Compound 3: middle estimate off by 7.1-fold (0.85 log units), on the high side, outside the stated range (below it).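

On an amide-type nitrogen of this core, the aryl group matters: pyridin-2-yl in place of 3-hydroxyphenyl gives a 6.2-fold lower number from compound 2 to compound 3 (0.79 log units; beyond the scatter) in this assay. The hydrogen-bond donor of 3-hydroxyphenyl is therefore not required for activity at this level, as pyridin-2-yl has none. No measured property shown here accounts for the step.

Still open, going by these compounds, is whether the lower number follows from the ring nitrogen or from the loss of the hydroxyl. Plain phenyl and pyridin-3-yl on the same nitrogen would separate these two readings.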